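The source may hold more compounds than are shown below. What is called first, only, known or untested is meant among the compounds shown, and "the series" means these compounds.

Compound 1 `Cc1cc(Nc2cc(-c3ccccc3)[nH]n2)n2nc(SCCc3ccccc3)nc2n1`: 37400 nM
Compound 2 `Cc1cc(Nc2cc(-c3ccccc3)[nH]n2)n2nc(SCc3ccc([N+](=O)[O-])cc3)nc2n1`: 43600 nM
Compound 3 `Cc1cc(Nc2cc(-c3ccccc3)[nH]n2)n2nc(SCC(=O)c3ccccc3)nc2n1`: 33300 nM

All three numbers come from an ADME assay on GES1 cells (Homo sapiens) for inhibition, read by MTT assay, with a stated time of 72 h; on this read-out higher numbers stand for weaker inhibition and lower numbers for stronger inhibition. Among them compound 1 stands second highest of the three, nearest to compound 3 and furthest from compound 2; the steps of a 1.1-fold lower number from compound 1 to compound 3 (0.05 log units; within the scatter) and a 1.2-fold higher number from compound 1 to compound 2 (0.07 log units; within the scatter) are both within the scatter, as is a 1.3-fold lower number from compound 2 to compound 3 (0.12 log units; within the scatter). Compound 4 `C#CCSc1nc2nc(C)cc(Nc3cc(-c4ccccc4)[nH]n3)n2n1` differs from compound 1 by ethynyl in place of benzyl on a saturated chain carbon bound to a sulfur. The three measured steps all swap the group on a saturated chain carbon bound to a sulfur, and none of them moved the number beyond the scatter, so the step is expected to be a 1.1-fold higher number from compound 1 to compound 4 (0.03 log units; within the scatter), with no direction beyond the scatter. Compound 4 is therefore estimated at 40000 nM in this assay, within a range from 15000 nM to 100000 nM.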

Compound 4, half-maximal inhibitory concentration: 45700 nM
Estimate against measurement, compound 4: 1.1-fold (0.06 log units) below, within the range that was stated.
By their numbers in this assay, from the lowest: compounds 3, 1, 2 and 4 (each within the scatter of the next).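

In this assay, ethynyl, which carries no ring, gives the same picture as the three groups with a six-membered aromatic ring (a 1.2-fold higher number from compound 1 to compound 4 (0.09 log units; within the scatter)) (a 1.4-fold higher number from compound 3 to compound 4 (0.14 log units; within the scatter)) (a 1.0-fold higher number from compound 2 to compound 4 (0.02 log units; within the scatter)). The earlier compounds shown here all kept such a ring on this saturated chain carbon bound to a sulfur, so only compound 4 shows that the number stays within the scatter without one. No measurement on hand offers an explanation for this. Open, on these data alone, is whether an amine or a carboxylic acid at this place would move the number beyond the scatter.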